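A few compounds are considered here, and "the series" means these few. Any claim that something is new, unique, unknown or untested is made for them only; others in the source may bear on it.

Of the compounds shown here, three sharing one core have been measured in a functional assay on the whole organism with Rattus norvegicus as the target, read by paw edema, with a stated time of 3 h, at a dose of 100 mg/kg by the oral route; a lower number here means less inhibition, a higher number more inhibition at the dose given (going by the name of the read-out). Compound 1 `Cc1ccc(-c2nc3ccccc3[nH]2)nc1` gives 19% in this assay. Compound 2 `CCc1ccc(-c2nc3ccccc3[nH]2)nc1` gives 44% in this assay, the highest of the three numbers, although compound 3 `CCc1cccc(-c2nc3ccccc3[nH]2)n1`, which gives 41% in this assay, lies within the scatter of it, so the two cannot be ranked; only compound 1 sits clearly lower. Going by the values given here, the single step between measured compounds that differ in one place is a number 25 percentage points higher from compound 1 to compound 2 (beyond the scatter), a modest change that lies beyond the scatter.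

Compound 4 `CCCCc1ccc(-c2nc3ccccc3[nH]2)nc1` has not yet been measured. It differs from compound 2 by ethyl in place of hydrogen on a saturated chain carbon, two bonds along the chain from an aromatic carbon. The step from compound 1 to compound 2 bears on this change, since it too lengthened the chain attached to the core, and it moved the number upward by a modest amount. Among the compounds with values here, whether a further lengthening continues that movement cannot be read from these three compounds, because no measured pair shows a chain longer than ethyl. In this assay a step of a number 6 percentage points higher from compound 2 to compound 4 (within the scatter) is therefore expected, a small rise or none beyond the scatter. Compound 4 is expected to give 50%, within a range from 30% to 70%.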

Compound 4, a percentage reported as inhibition, in the whole organism at one dose (the size of the read-out at that dose, not a potency): -16%
Compound 4: middle estimate off by 66 percentage points, on the high side; the measured number lies below the stated range.
By their numbers in this assay, from the lowest: compound 4; then compound 1; then compounds 3 and 2 (each within the scatter of the next).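

The butyl chain of compound 4 turns back the upward movement seen on the shorter chains: in this assay there is a number 60 percentage points lower from compound 2 to compound 4 (beyond the scatter), whereas the earlier lengthening gave a number 25 percentage points higher from compound 1 to compound 2 (beyond the scatter). The fall also carries past the methyl compound, with a number 35 percentage points lower from compound 1 to compound 4 (beyond the scatter), so across these three compounds the number does not follow chain length in one direction, rising from methyl to ethyl and then falling from ethyl to butyl, and compound 4 gives -16% in this assay, a number on the far side of zero rather than merely a smaller inhibition. No measurement available here bears on why lengthening the chain from ethyl to butyl has this effect.

Where between ethyl and butyl the number turns remains open, and a propyl chain in the same place would speak to that, as a longer chain such as hexyl would speak to whether the fall continues. Also open, from the compounds shown here alone, is whether an amine or a carboxylic acid at the end of the butyl chain would change the outcome, and whether the butyl chain would act the same way in the arrangement of compound 3.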